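Cytotoxicity limits across the benzyl series

A few compounds are considered here, and "the series" means these few. Any claim that something is new, unique, unknown or untested is made for them only; others in the source may bear on it.

Measured in an ADME assay on 2209-23 cells (Homo sapiens) for cytotoxicity, read by WST assay and thymidine incorporation; on this read-out higher numbers stand for lower toxicity in this test and lower numbers for higher toxicity in this test:
- compound 1 `CC(C)(C)[C@H]1C(O)=C(C2=CS(=O)(=O)c3cc(NS(C)(=O)=O)ccc3N2)C(=O)N1Cc1ccc(F)cc1F`: > 50000 nM
- compound 2 `Cc1cc(CN2C(=O)C(C3=CS(=O)(=O)c4cc(NS(C)(=O)=O)ccc4N3)=C(O)[C@@H]2C(C)(C)C)ccc1F`: > 50000 nM
- compound 3 `CC(C)(C)[C@H]1C(O)=C(C2=CS(=O)(=O)c3cc(NS(C)(=O)=O)ccc3N2)C(=O)N1Cc1ccccc1`: > 50000 nM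

Each of these entries is a limit of the assay and not a number. Compound 3 stands at > 50000 nM, which is only a limit. Compound 1 and compound 2 also stand only as limits, so the three compounds cannot be ranked. The overall picture is the limit of > 50000 nM in this assay, at which 3 of the 3 values shown sit.

Compound 4 `CC(C)(C)[C@H]1C(O)=C(C2=CS(=O)(=O)c3cc(NS(C)(=O)=O)ccc3N2)C(=O)N1Cc1ccc(F)c(Cl)c1` is still to be measured in this assay. The change is 3-chloro-4-fluorophenyl in place of phenyl on a saturated chain carbon bound to an amide-type nitrogen in a ring: benzyl to 3-chloro-4-fluorobenzyl, on a saturated chain carbon bound to an amide-type nitrogen in a ring.

Three measured steps change the aromatic group at this same place: a step that the two limits leave unreadable from compound 1 to compound 3, a step that the two limits leave unreadable from compound 2 to compound 3 and a step that the two limits leave unreadable from compound 1 to compound 2. None has a readable size, so they give no measured size or direction to carry over. Compound 1 and compound 2 both carry substituted phenyl groups here, and neither has left the limit, as a step that the two limits leave unreadable from compound 1 to compound 3 and a step that the two limits leave unreadable from compound 2 to compound 3 show. No step beyond the usual scatter is therefore expected, and another limit is the likely report. The step expected is a step that the limit leaves unreadable from compound 3 to compound 4. For compound 4 the estimated value is 60000 nM, with an expected range from 30000 nM to 120000 nM.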

Compound 4, half-maximal cytotoxic concentration: > 50000 nM
Compound 4: no number, only a limit (the forecaster's own chance of this, stated with the estimate: 85%); the middle value is on the limit's open side.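

Compound 4 is also only a limit and not a number in this assay, like compound 1, compound 2 and compound 3, so no new step can be read among these compounds: the limit of > 50000 nM in this assay, at which 4 of the 4 values shown sit.

The compounds shown leave open whether the four differ at all in cytotoxicity, and whether any aromatic group at this place would bring a readable number.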